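The source may hold more compounds than are shown below. What is called first, only, known or untested is meant among the compounds shown, and "the series" means these compounds.

Three compounds sharing one core have been examined in an assay on HEK293 cells for activation of Kir3.1/Kir3.2 (Homo sapiens), read by thallium flux; on this read-out higher numbers stand for an effect only at larger amounts of compound and lower numbers for an effect already at smaller amounts. Compound 1 `Cc1cc(NC(=O)Cn2nnc(-c3cccc(Cl)c3)n2)n(C2CCCCC2)n1` gives 300 nM, compound 2 `Cc1cc(NC(=O)Cn2nnc(-c3cc(Cl)cc(Cl)c3)n2)n(C2CCCCC2)n1` gives 980 nM, and compound 3 `Cc1cc(NC(=O)Cn2nnc(-c3ccc(F)cc3)n2)n(C2CCCCC2)n1` gives 180 nM. Compound 3 holds the lowest of the three numbers, though its separation from compound 1 is within the scatter; only its gap to compound 2 is clear, as seen in a 5.4-fold lower number from compound 2 to compound 3 (0.74 log units; beyond the scatter). The step of a 3.3-fold higher number from compound 1 to compound 2 (0.51 log units; beyond the scatter) shows what an extra chloro on the phenyl does, while a 1.7-fold lower number from compound 1 to compound 3 (0.22 log units; within the scatter) shows that moving between a chlorinated and a fluorinated phenyl changes little.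

Compound 4 `Cc1cc(NC(=O)Cn2nnc(-c3cccc(F)n3)n2)n(C2CCCCC2)n1` differs from compound 3 by 6-fluoropyridin-2-yl in place of 4-fluorophenyl on an aromatic carbon. Among the measured compounds shown here, none of the measured steps concerns such a swap of a carbon-only ring for a ring carrying one hetero atom and one hydrogen-bond acceptor; they all vary halogens on a phenyl. For the measured compounds named here, with no direct precedent, the expectation for compound 4 is a step of about a 1.4-fold higher number from compound 3 to compound 4 (0.14 log units; within the scatter), within the scatter, so compound 4 is estimated at 250 nM, plausibly between 90 nM and 700 nM.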

Compound 4, half-maximal effective concentration: > 3000 nM
Compound 4: no number, only a limit; the forecaster's own chance of this, stated with the estimate: 5%; middle value at least 12-fold (1.07 log units) from the limit.
By their numbers in this assay, from the lowest: compounds 3 and 1 (each within the scatter of the next); then compound 2. At a limit, above all of these: compound 4.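

In this assay, compound 4 gives no number, only a limit of the assay: the limit of > 3000 nM in this assay, at which 1 of the 4 values shown sits. Even so, the step of an at least 16-fold higher number from compound 3 to compound 4 (1.22 log units; beyond the scatter) is larger than any step among the phenyl compounds, the widest of which was a 5.4-fold lower number from compound 2 to compound 3 (0.74 log units; beyond the scatter), and the same swap also separates compound 4 from the other two, with an at least 10-fold higher number from compound 1 to compound 4 (1.00 log units; beyond the scatter) and an at least 3.0-fold higher number from compound 2 to compound 4 (0.48 log units; beyond the scatter). On this aromatic carbon, then, halogen changes on the phenyl shifted the number only moderately, whereas entry of 6-fluoropyridin-2-yl, with the same count of 7 heavy atoms, pushed it past all three earlier values.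

The compounds shown leave open whether the ring nitrogen or the different place of the fluoro substituent accounts for this step. Neither an unsubstituted pyridin-2-yl nor a 3-fluorophenyl group is among them to separate the two.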